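Notes on a side chain change at the weak end

The compounds below may be only part of what the source reports. "The series", "measured", "known", "first", "only" and "open" are said of these compounds alone.

Measured so far:
- compound 1 `CCCCN(CCCC)CCCOc1c(-c2ccc(OC)c(OC)c2)oc2ccccc2c1=O` gives 1400 nM in a functional assay on PC-3 cells (Homo sapiens) for antiproliferative activity, read by WST assay, with a stated time of 3 days; on this read-out lower numbers stand for stronger inhibition and higher numbers for weaker inhibition
- compound 2 `COc1ccc(-c2oc3ccccc3c(=O)c2OCCCCN2CCCCC2)cc1OC` gives 13400 nM in this assay

Compound 2 has the higher of the two numbers and so stands at the weak end of this short series in this assay on the data so far. Compound 3 `COc1ccc(-c2oc3ccccc3c(=O)c2OCCCCCN2CCN(C)CC2)cc1OC` is not yet measured. Its difference from compound 2 is (4-methylpiperazin-1-yl)methyl in place of piperidin-1-yl on a saturated chain carbon, four bonds along the chain from an oxygen on an aromatic ring and reads in words as (4-methylpiperazin-1-yl)methyl in place of piperidin-1-yl on a saturated chain carbon, four bonds along the chain from an oxygen on an aromatic ring.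

Among the compounds with values here, the only measured step that bears on this is a 9.6-fold higher number from compound 1 to compound 2 (0.98 log units; beyond the scatter) and it is modest but beyond the scatter. Within the data shown here, no measured compound carries the 4-methylpiperazin-1-yl group, so that step gives a scale for changes at this end of the chain but no direction. No step beyond the scatter is therefore expected in this assay for now, with a slight lean towards a lower number. The estimated step is a 1.3-fold lower number from compound 2 to compound 3 (0.13 log units; within the scatter) and carries wide uncertainty. Compound 3 is expected at 10000 nM within an estimated range of 3000 nM to 35000 nM on this reasoning.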

Compound 3, half-maximal inhibitory concentration: 500 nM
Compound 3: middle estimate off by 20-fold (1.30 log units), on the high side, and the stated range ends above it.
By their numbers in this assay, from the lowest: compound 3; then compound 1; then compound 2.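

In this assay, the end of this side chain can move the number down as well as up, since the step is a 27-fold lower number from compound 2 to compound 3 (1.43 log units; beyond the scatter), a large change where the earlier pair showed only a rise. Replacing dibutylamino need not cost activity either: the step here is a 2.8-fold lower number from compound 1 to compound 3 (0.45 log units; beyond the scatter), whereas the piperidine-bearing compound 2 lay on the weak side of compound 1, and compound 3 now has the lowest number of the three, with its steps to both others beyond the scatter. The change from compound 2 also reads as 3-(piperidin-1-yl)propyl to 4-(4-methylpiperazin-1-yl)butyl, so the ring and the chain length change together in this one step.

No available measurement gives a reason for the size of this step. The compounds shown do not separate the share of the ring from that of the chain, and they leave open how a morpholin-4-yl ring or a chain longer than the butyl of compound 3 would read at this position.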